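Adding a methyl to the amine nitrogen of compound 3

The source may report more compounds than this note shows. Statements on the series, on what has been measured and on what is new or still open speak of the compounds shown alone.

Measured so far in an in vitro assay on 293-EBNA cells for binding affinity to corticotropin-releasing factor receptor 1 (Homo sapiens); on this read-out higher numbers stand for weaker inhibition and lower numbers for stronger inhibition:
Compound 1, `CCC(COC)N(C)c1nc(C)nc2c1nnn2-c1ccc(C(C)C)cc1Br`, gives 11.2 nM.
Compound 2, `Cc1nc(N2CCCC2)c2nnn(-c3ccc(C(C)C)cc3Br)c2n1`, gives 194 nM.
Compound 3, `COCC(COC)Nc1nc(C)nc2c1nnn2-c1ccc(C(C)C)cc1Br`, gives 10.3 nM.

Among these three, compound 3 carries the lowest number, but its neighbour compound 1 sits very close: a 1.1-fold lower number from compound 1 to compound 3 (0.04 log units; within the scatter). The only large movement in the set is the change to the cyclic amine in compound 2: a 17-fold higher number from compound 1 to compound 2 (1.24 log units; beyond the scatter) and a 19-fold lower number from compound 2 to compound 3 (1.27 log units; beyond the scatter).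

Compound 4, `COCC(COC)N(C)c1nc(C)nc2c1nnn2-c1ccc(C(C)C)cc1Br`, differs from compound 3 by methyl in place of hydrogen on a nitrogen on an aromatic ring. For the measured compounds named here, no measured step changes exactly this: compound 1 already carries a methyl on that nitrogen, yet its chain differs from that of compound 3, so the step from compound 1 to compound 3 blends two changes and still stays within the scatter. That suggests the open-chain amines here tolerate small variation, while the large shift belongs only to the ring of compound 2. The expected step of a 1.1-fold higher number from compound 3 to compound 4 (0.03 log units; within the scatter) is therefore none beyond the scatter, in either direction. Compound 4 is estimated at 11 nM, with a range from 4 nM to 30 nM.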

Compound 4, inhibition constant: 21.3 nM
Estimate against measurement, compound 4: 1.9-fold (0.29 log units) below; the measured number falls inside the stated range.
By their numbers in this assay, from the lowest: compounds 3, 1 and 4 (each within the scatter of the next, the first and the last beyond it); then compound 2.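

Methyl in place of hydrogen on this nitrogen, read directly in this assay with the chain held constant, gives a 2.1-fold higher number from compound 3 to compound 4 (0.32 log units; beyond the scatter) as a modest cost, so this nitrogen is less indifferent to change than the earlier compounds suggested. With that methyl present on both compounds, methoxy in place of methyl on the chain gives a 1.9-fold higher number from compound 1 to compound 4 (0.28 log units; within the scatter) and so no difference that can be told from the scatter. Even with the methyl, the open chain keeps a clear edge over pyrrolidin-1-yl, with a 9.1-fold lower number from compound 2 to compound 4 (0.96 log units; beyond the scatter) as the step.

Nothing available here explains why the methyl costs anything. The compounds shown leave open how an ethyl on this nitrogen would fare, and whether the chain of compound 1 would respond to losing its methyl in the same way.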